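A few compounds are considered here, and "the series" means these few. Any claim that something is new, unique, unknown or untested is made for them only; others in the source may bear on it.

Compound 1 `Cc1cccnc1-c1ccc(C(=O)Nc2ccc(C(C)C)cc2)cc1`: 73 nM
Compound 2 `CC(C)(C)c1ccc(NC(=O)c2ccc(-c3ncccc3C#N)cc2)cc1`: 30 nM

Both were run in a functional assay for antagonist activity at transient receptor potential cation channel subfamily V member 1 (Homo sapiens), read by FLIPR; a lower number here means a stronger inhibitor, a higher number a weaker inhibitor. Of the two numbers, compound 2 gives the lowest; compound 1 sits a step above it, and that gap lies beyond the usual scatter of repeated measurements. Compound 3 `CC(C)(C)c1ccc(NC(=O)c2ccc(-c3ncccc3-c3nn[nH]n3)cc2)cc1` is the next entry and has not yet been measured. It differs from compound 2 in one place: 2H-tetrazol-5-yl in place of cyano on an aromatic carbon. For the measured compounds named here, no pair of measured compounds shows this exchange, so no measured step speaks to it; the two measured compounds differ from each other in another place and carry no information about this one. The expectation for compound 3 is a weaker inhibitor than compound 2, with an expected step of a 10-fold higher number from compound 2 to compound 3 (1.00 log units; beyond the scatter) that would lie beyond the scatter. For compound 3 the estimate in this assay is 300 nM, with an expected range from 60 nM to 2000 nM.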

Compound 3, half-maximal inhibitory concentration: > 4000 nM
Compound 3 gave a limit, no number (the forecaster's own chance of this, stated with the estimate: 10%); middle value at least 13-fold (1.12 log units) away from the limit.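

At this position, on an aromatic carbon ortho to a large group and two atoms from the ring nitrogen, the cyano group cannot be exchanged freely: in this assay, 2H-tetrazol-5-yl in its place gives an at least 130-fold higher number from compound 2 to compound 3 (2.12 log units; beyond the scatter). Compound 3 stands at a limit of the assay, > 4000 nM, and this is not a number. The step is therefore a lower bound on the loss, and its full size cannot be read: the limit of > 4000 nM in this assay, at which 1 of the 3 values shown sits.

The exchange changes size, ring count and hydrogen-bond donors at once, so the compounds shown do not separate which of these differences matters. On these data alone, whether a carboxylic acid, a primary amide or a methoxy group on this carbon would stay near compound 2 remains open.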